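Sulfonamide series: from 2-hydroxyethyl to benzyl

This account rests on a few compounds, and the source may have more. Where it says the series, first, only, none or still open, it means among the compounds named here.

Compound 1 `CS(=O)(=O)c1cccc(Nc2ccc3nccc(-c4ccncc4)c3n2)c1`: > 50000 nM, a limit of the assay
Compound 2 `O=S(=O)(NCCO)c1cccc(Nc2ccc3nccc(-c4ccncc4)c3n2)c1`: 4000 nM

Both values come from an ADME assay on CHO cells (Cricetulus griseus) for cytotoxicity, read by MTT assay; on this read-out higher numbers stand for weaker inhibition and lower numbers for stronger inhibition. For compound 1 the entry is a limit: the limit of > 50000 nM in this assay, at which 1 of the 2 values shown sits. Among the compounds with values here, compound 2, at 4000 nM, therefore holds the only actual number so far.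

Compound 3 `O=S(=O)(NCc1ccccc1)c1cccc(Nc2ccc3nccc(-c4ccncc4)c3n2)c1` carries phenyl in place of hydroxymethyl on a saturated chain carbon bound to a sulfonamide nitrogen, which amounts to 2-hydroxyethyl to benzyl.

Within the data shown here, one measured step bears on this change: an at least 12-fold lower number from compound 1 to compound 2 (1.09 log units; beyond the scatter). It is large and beyond the scatter, but it starts from a limit and gives a direction rather than a size. Following it, a smaller step toward a lower number is expected in this assay, possibly one within the scatter. The expected step is a 1.6-fold lower number from compound 2 to compound 3 (0.20 log units; within the scatter). For compound 3 the estimated value is 2500 nM, with an expected range of 700 nM to 10000 nM.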

Compound 3, half-maximal inhibitory concentration in the CHO assay: > 50000 nM
Compound 3: a limit, no number (the forecaster's own chance of this, stated with the estimate: 8%); middle value at least 20-fold (1.30 log units) away from the limit.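

In the CHO assay, phenyl in place of hydroxymethyl on the saturated chain carbon bound to the sulfonamide nitrogen gives an at least 12-fold higher number from compound 2 to compound 3 (1.09 log units; beyond the scatter), so a sulfonamide nitrogen alone does not go with the lower number of compound 2, and the group on that nitrogen matters. Compound 3 stands at a limit, as does compound 1, and the step between these two cannot be read: the limit of > 50000 nM in the CHO assay, at which 2 of the 3 values shown sit.

In a physicochemical assay for solubility, read by HPLC, using the shake flask method, measured as kinetic solubility, with a stated time of 20 h, at pH 6.5, tested at 200 uM (a higher number here means a more soluble compound, a lower number a less soluble compound), compound 2 gives 115000 nM. In the physicochemical assay, compound 3 gives < 5000 nM, and this entry is again a limit: the limit of < 5000 nM in the physicochemical assay, at which 1 of the 2 values shown sits.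

In the physicochemical assay, the same change gives an at least 23-fold lower number from compound 2 to compound 3 (1.36 log units; beyond the scatter).

The compounds shown do not separate the solubility of compound 3 from the benzyl group itself as the link to its result in the CHO assay. A longer chain ending in hydroxyl, or a chain carrying an amine or a carboxylic acid, would test whether the number of compound 2 depends on the hydroxymethyl.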